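Thiosemicarbazone series: aryl substituent and cytotoxicity

The source may report more compounds than this note shows. Statements on the series, on what has been measured and on what is new or still open speak of the compounds shown alone.

Measured compounds:
- compound 1, `CC1=CC[C@@H]([C@@](C)(O)CCCC(C)(C)NC(=S)NN)CC1`: > 100000 nM (a limit)
- compound 2, `CC1=CC[C@@H]([C@@](C)(O)CCCC(C)(C)NC(=S)N/N=C\c2ccccc2)CC1`: 48400 nM
- compound 3, `COc1ccc(/C=N\NC(=S)NC(C)(C)CCC[C@](C)(O)[C@@H]2CC=C(C)CC2)cc1`: 48500 nM

In a functional assay on UACC-62 cells (Homo sapiens) for cytotoxicity, read by sulforhodamine B assay (on this read-out higher numbers stand for lower toxicity in this test and lower numbers for higher toxicity in this test), compound 1 gives > 100000 nM, which is a limit of the assay and not a number (the limit of > 100000 nM in this assay, at which 1 of the 3 values shown sits). Compound 2 gives 48400 nM and compound 3 gives 48500 nM. Among the two numbers shown, compound 3 holds the higher one, but the gap to compound 2 is within the scatter a 1.0-fold higher number from compound 2 to compound 3 (0.00 log units; within the scatter). Replacing the terminal nitrogen of compound 1 with the benzylidene group gives an at least modest lower number an at least 2.0-fold lower number from compound 1 to compound 2 (0.31 log units; beyond the scatter), and with the methoxybenzylidene group likewise an at least 2.0-fold lower number from compound 1 to compound 3 (0.31 log units; beyond the scatter).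

Compound 4, `CC1=CC[C@@H]([C@@](C)(O)CCCC(C)(C)NC(=S)N/N=C\c2ccc(O)cc2)CC1`, differs from compound 3 by hydrogen in place of methyl on an oxygen on an aromatic ring. For the measured compounds named here, the only measured step that bears on a change at this aromatic position is the methoxy for hydrogen step, which lay within the scatter a 1.0-fold higher number from compound 2 to compound 3 (0.00 log units; within the scatter). For compound 4, therefore, no step beyond the scatter in this assay is expected: a 1.0-fold lower number from compound 3 to compound 4 (0.00 log units; within the scatter). Compound 4 is estimated at 48000 nM, in a range from 20000 nM to 115000 nM.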

Compound 4, concentration lethal to 50% of the cells: 55600 nM
The estimate for compound 4 lay 1.2-fold (0.06 log units) below the measured number, and the stated range covers the measured number.
By their numbers in this assay, from the lowest: compounds 2, 3 and 4 (each within the scatter of the next). At a limit, above all of these: compound 1.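

In this assay, the third group tried at this aromatic position, hydroxy, stays level with both methoxy and hydrogen: a 1.1-fold higher number from compound 3 to compound 4 (0.06 log units; within the scatter), and a 1.1-fold higher number from compound 2 to compound 4 (0.06 log units; within the scatter). The value of compound 1 is a limit of the assay and not a number: the limit of > 100000 nM in this assay, at which 1 of the 4 values shown sits. Against that limit, an at least 1.7-fold lower number from compound 1 to compound 4 (0.25 log units; that floor lies within the scatter), so compound 4, unlike compound 2 and compound 3, has no step from compound 1 that is shown to lie beyond the scatter.

From the compounds shown here alone, whether an amine, a carboxylic acid or a chlorine atom in place of the hydroxy would move the number beyond the scatter remains open. Also open, going by these compounds, is whether a longer chain on the oxygen, in place of the methyl of compound 3, would do so.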